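A few compounds are considered here, and "the series" means these few. Any claim that something is new, unique, unknown or untested is made for them only; others in the source may bear on it.

Three compounds of this set were brought into an ADME assay on Vero cells (Chlorocebus sabaeus) for cytotoxicity; a lower number here means that less compound is tolerated, a higher number that more compound is tolerated. Compound 2 `Nc1nccc(-c2c(-c3ccc(F)cc3)nn3c(NC4CCCC4)cccc23)n1` is the only one of them with a number: in this assay compound 2 gives 46000 nM. For compound 1 `Nc1nc(-c2c(-c3ccc(F)cc3)nn3c(NC4CCCC4)cccc23)c[nH]1` the entry in this assay reads "not determined" (no result reported), and for compound 3 `Fc1ccc(-c2nn3c(NC4CCCC4)cccc3c2-c2ccco2)cc1` the entry in this assay likewise reads "not determined" (no result reported); so where compound 3 lies in this read-out is not known, and nothing can be said of how it compares with compound 2.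

The step considered here leads from compound 3 to compound 4 `Fc1ccc(-c2nn3c(NC4CCCC4)cccc3c2-c2cc[nH]n2)cc1`. The change is 1H-pyrazol-3-yl in place of furan-2-yl on an aromatic carbon. The groups that leave and enter have the same count of heavy atoms, and the entering one brings one hydrogen-bond donor where the leaving one had none.

Among the measured compounds shown here, no measured pair in this set shows what such a change does in this assay, and the starting point, compound 3, has no number of its own. The only anchor is the shared core, for which compound 2 gives 46000 nM in this assay. On that basis compound 4 is expected to sit near the value of compound 2, with no direction of change that can be argued for. The estimate for compound 4 in this assay is 40000 nM, within a range from 12000 nM to 100000 nM.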

Compound 4, half-maximal cytotoxic concentration: 14000 nM
Compound 4: the middle estimate sits 2.9-fold (0.46 log units) above what was measured, within the range that was stated.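

In this assay the group on this aromatic carbon proves not to be neutral: with the rest of the structure held constant, 1H-pyrazol-3-yl in place of 2-aminopyrimidin-4-yl gives a 3.3-fold lower number from compound 2 to compound 4 (0.52 log units; beyond the scatter), so less of compound 4 is tolerated. Among the compounds shown here, this is the first readable comparison at this position, whereas the change from furan-2-yl to 1H-pyrazol-3-yl and any step involving compound 1 cannot be read, as compound 3 and compound 1 have no number in this read-out. Nothing available accounts for the difference between compound 2 and compound 4.

The compounds shown leave open whether the hydrogen-bond donor of 1H-pyrazol-3-yl has any bearing on tolerance, since the furan-2-yl compound offers no value against which to set it. They also leave open whether the difference follows the amine of 2-aminopyrimidin-4-yl or the rest of that group, a question that an unsubstituted pyrimidin-4-yl or a 1-methylpyrazol-3-yl group at the same carbon would help to address.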